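This account rests on a few compounds, and the source may have more. Where it says the series, first, only, none or still open, it means among the compounds named here.

Working notes on the series. Of the compounds shown here, three on the shared core have been read in a functional assay on MT4 cells (Homo sapiens) for cytotoxicity; on this read-out lower numbers stand for higher toxicity in this test and higher numbers for lower toxicity in this test. Compound 1 `Cc1cn([C@@H]2O[C@H](CO[Si](C)(C)C(C)(C)C)[C@@]3(OS(=O)(=O)C(I)=C3N)[C@H]2O[Si](C)(C)C(C)(C)C)c(=O)n(C)c1=O`, carrying iodo, gives 3900 nM. Compound 2 `C=CCC1=C(N)[C@@]2(OS1(=O)=O)[C@@H](CO[Si](C)(C)C(C)(C)C)O[C@@H](n1cc(C)c(=O)n(C)c1=O)[C@@H]2O[Si](C)(C)C(C)(C)C`, carrying allyl, gives 82000 nM. Compound 3 `Cc1cn([C@@H]2O[C@H](CO[Si](C)(C)C(C)(C)C)[C@@]3(OS(=O)(=O)C(c4ccsc4)=C3N)[C@H]2O[Si](C)(C)C(C)(C)C)c(=O)n(C)c1=O`, carrying thiophen-3-yl, gives 3900 nM, level with compound 1 and sharing the low end of the three numbers with it.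

The next change leads to compound 4 `CC#CC1=C(N)[C@@]2(OS1(=O)=O)[C@@H](CO[Si](C)(C)C(C)(C)C)O[C@@H](n1cc(C)c(=O)n(C)c1=O)[C@@H]2O[Si](C)(C)C(C)(C)C`: prop-1-yn-1-yl in place of thiophen-3-yl on a double-bonded ring carbon. In words, prop-1-yn-1-yl replaces thiophen-3-yl on a double-bonded ring carbon.

All three measured steps were made at this same carbon. The step of no change at the digits printed from compound 1 to compound 3 (within the scatter) stays within the scatter, whereas a 21-fold higher number from compound 1 to compound 2 (1.32 log units; beyond the scatter) and a 21-fold lower number from compound 2 to compound 3 (1.32 log units; beyond the scatter) are both large. Iodo and thiophen-3-yl therefore read alike, and allyl alone departs from them. The entering prop-1-yn-1-yl has no ring, and the only ring-free carbon chain measured so far is the allyl of compound 2 at 82000 nM. With a single such comparison, the direction is tentative, and a moderate rise is expected rather than the full size of that jump. The expected step is a 3.8-fold higher number from compound 3 to compound 4 (0.59 log units; beyond the scatter). For compound 4 the estimated value is 15000 nM, with an expected range of 3500 nM to 70000 nM.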

Compound 4, half-maximal cytotoxic concentration: 3300 nM
Compound 4: middle estimate off by 4.5-fold (0.66 log units), on the high side, outside the stated range (below it).
By their numbers in this assay, from the lowest: compounds 4, 1 and 3 (each within the scatter of the next); then compound 2.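

In this assay the exchange gives a 1.2-fold lower number from compound 3 to compound 4 (0.07 log units; within the scatter) and a 1.2-fold lower number from compound 1 to compound 4 (0.07 log units; within the scatter), so at this double-bonded ring carbon prop-1-yn-1-yl reads alike with both thiophen-3-yl and iodo. Against allyl the picture is different, with a 25-fold lower number from compound 2 to compound 4 (1.40 log units; beyond the scatter), which shows that the absence of a ring does not by itself separate a group from iodo and thiophen-3-yl at this position. Among these compounds, compound 1, compound 3 and compound 4 now form a single level across a halogen, an aromatic ring and a triple-bonded chain, and compound 2 is the only compound that goes against this pattern.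

Nothing in the data shown accounts for the departure of allyl from the other three groups. Going by these compounds, it remains open whether the high number belongs to allyl alone or also appears with a saturated chain such as propyl or a longer chain, and how an amine or a carboxylic acid at this carbon would read on the shared core.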